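This account rests on a few compounds, and the source may have more. Where it says the series, first, only, none or still open, it means among the compounds named here.

Measured in a functional assay on HCT-116 cells (Homo sapiens) for antiproliferative activity, read by MTT assay, with a stated time of 72 h; a higher number here means a weaker inhibitor, a lower number a stronger inhibitor:
- compound 1 `Nc1nc(N)c2cc(CSC(=S)N3CCN(c4ccc(O)cc4)CC3)ccc2n1`: 5980 nM
- compound 2 `Cc1ccc(N2CCN(C(=S)SCc3ccc4nc(N)nc(N)c4c3)CC2)cc1`: 5510 nM
- compound 3 `Nc1nc(N)c2cc(CSC(=S)N3CCN(c4ccc(Cl)cc4)CC3)ccc2n1`: 7380 nM

Compound 3, at 7380 nM, cannot be separated from its two relatives: a 1.2-fold higher number from compound 1 to compound 3 (0.09 log units; within the scatter), and a 1.3-fold higher number from compound 2 to compound 3 (0.13 log units; within the scatter). Compound 4 `Nc1nc(N)c2cc(CSC(=S)N3CCN(c4ccc(Cl)c(Cl)c4)CC3)ccc2n1` is the next case, with chloro in place of hydrogen on an aromatic carbon. The group changes from 4-chlorophenyl to 3,4-dichlorophenyl.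

The closest evidence is the swaps among the measured compounds, such as a 1.1-fold lower number from compound 1 to compound 2 (0.04 log units; within the scatter). All of them were small, but each replaced one group with another, and none added a second group, so they guide this change only loosely. The expected step is a 1.2-fold lower number from compound 3 to compound 4 (0.09 log units; within the scatter), with nothing expected beyond the scatter. Compound 4 is estimated at 6000 nM, with an expected range of 2800 nM to 11000 nM.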

Compound 4, half-maximal inhibitory concentration: 6680 nM
Estimate against measurement, compound 4: 1.1-fold (0.05 log units) below, and the stated range covers the measured number.
By their numbers in this assay, from the lowest: compounds 2, 1, 4 and 3 (each within the scatter of the next).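

Adding a second chloro, rather than swapping one group for another, is new here, and it gives a 1.1-fold lower number from compound 3 to compound 4 (0.04 log units; within the scatter) in this assay at the ring carbon ortho to the first chloro group. The 3,4-dichlorophenyl compound also stays level with the other two, with a 1.2-fold higher number from compound 2 to compound 4 (0.08 log units; within the scatter) and a 1.1-fold higher number from compound 1 to compound 4 (0.05 log units; within the scatter) both leaving it inseparable, so this added chloro leaves the number unmoved. Nothing measured here explains this flat result.

As far as these compounds go, whether another group added on that carbon, such as an amine or a carboxylic acid, would move the number beyond the scatter remains open.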